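Working notes: one aryl position varied, maximal response followed

The source may hold more compounds than are shown below. What is called first, only, known or untested is meant among the compounds shown, and "the series" means these compounds.

All values below come from an in vitro functional assay on HEK285-7 cells for antagonist activity at prostaglandin D2 receptor 2 (Homo sapiens), read by BRET and beta-arrestin recruitment; a higher number here means a larger maximal response, a lower number a smaller maximal response.

compound 1 `O=C(O)Cc1sc(C(c2ccc(F)cc2)c2ccc(F)cc2)nc1-c1ccnc(N2CCCC2)c1` gives 80%
compound 2 `O=C(O)Cc1sc(C(c2ccccc2)c2ccc(Cl)cc2)nc1-c1ccc(F)cc1` gives 80%
compound 3 `O=C(O)Cc1sc(C(c2ccccc2)c2ccccc2)nc1-c1ccc(F)c(F)c1` gives 80%

In this assay compound 1 stands level with compound 2 and compound 3 at the digits shown; the nearest of the two is compound 2 and the furthest compound 3, and neither gap reaches beyond the usual scatter. Three different aryl groups on the same position of the shared core of compound 1 thus return the same maximal response, as far as these three compounds go.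

Compound 4 `NS(=O)(=O)c1cccc(-c2nc(C(c3ccc(F)cc3)c3ccc(F)cc3)sc2CC(=O)O)c1` is the next member to be measured. It differs from compound 1 in one place:

3-sulfamoylphenyl in place of 2-(pyrrolidin-1-yl)pyridin-4-yl on an aromatic carbon

For the measured compounds named here, no step between two measured compounds is available for this pair, so only the three values above can guide the expectation. Since compound 1, compound 2 and compound 3 all sit together in this assay with quite different groups at this position, no step beyond the scatter is expected in this assay for the change to compound 4, in either direction. The expected step from compound 1 to compound 4 is no change at the digits printed from compound 1 to compound 4 (within the scatter). Compound 4 is therefore estimated at 80% in this assay, with a range from 65% to 95%.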

Compound 4, largest response reached (reported as efficacy), in percent of the reference or control that the assay uses: 55%
For compound 4 the middle estimate is 25 percentage points above the measured one; measured number below the stated range.
By their numbers in this assay, from the lowest: compound 4; then compounds 1, 2 and 3 (each within the scatter of the next).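

In this assay, for the compounds shown here, replacing 2-(pyrrolidin-1-yl)pyridin-4-yl with 3-sulfamoylphenyl gives a number 25 percentage points lower from compound 1 to compound 4 (beyond the scatter), so the maximal response does depend on the group at this aromatic carbon, which the level values of the earlier compounds gave no sign of. The change swaps a pyridine ring carrying a pyrrolidine ring, with no hydrogen-bond donor, for a carbon-only aromatic ring carrying a sulfamoyl group, which brings one hydrogen-bond donor and a sulfur atom, and this single step cannot show which of these differences matters. Nothing at hand bears on the reason for the step.

On these data alone, it remains open whether the step belongs to the sulfamoyl group itself or to the loss of the 2-(pyrrolidin-1-yl)pyridin-4-yl group, a question that a methylsulfonyl group or a carboxylic acid in place of the sulfamoyl group on the same phenyl ring would help to settle. Also open, as far as these compounds go, is whether a plain phenyl group at this carbon, on the same core with its two 4-fluorophenyl groups, would stay with compound 1 or fall with compound 4.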